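This account rests on a few compounds, and the source may have more. Where it says the series, first, only, none or still open, it means among the compounds named here.

In a functional assay on HepG2 cells (Homo sapiens) for inhibition, read by MTT assay, with a stated time of 72 h (on this read-out higher numbers stand for weaker inhibition and lower numbers for stronger inhibition), the series so far reads:
- compound 1 `COc1cc(NC(C)CCCCCCNC(=O)CCC(=O)NO)c2ncccc2c1` gives 1600 nM
- compound 2 `COc1cc(NC(C)CCCNC(=O)CCC(=O)NO)c2ncccc2c1` gives 1600 nM

Compound 1 stands level with compound 2 at the digits shown, and neither can be ranked above the other. The next analogue, compound 3 `COc1cc(NC(C)CCCCCNC(=O)CCC(=O)NO)c2ncccc2c1`, carries ((2-(hydroxycarbamoyl)ethyl)carbonyl)amino in place of (((2-(hydroxycarbamoyl)ethyl)carbonyl)amino)methyl on a saturated chain carbon, six bonds along the chain from a nitrogen on an aromatic ring. For the measured compounds named here, no measured step yet sizes this change. Going by the values given here, with compound 1 at 1600 nM and compound 2 at 1600 nM as the only guides, no step beyond the scatter is expected in this assay, and no direction is favoured. The expected change is no change at the digits printed from compound 1 to compound 3 (within the scatter) in this estimate. The estimated value for compound 3 is 1600 nM, with an expected range of 700 nM to 3600 nM, still to be tested.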

Compound 3, half-maximal inhibitory concentration: 1600 nM
For compound 3 middle estimate and measured number coincide at the digits printed; measured number inside the range.
By their numbers in this assay, from the lowest: compounds 1, 2 and 3 (each within the scatter of the next).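

In this assay, ((2-(hydroxycarbamoyl)ethyl)carbonyl)amino in place of (((2-(hydroxycarbamoyl)ethyl)carbonyl)amino)methyl on a saturated chain carbon gives no change at the digits printed from compound 1 to compound 3 (within the scatter). For the compounds shown here, this is the first sized step at this position, and it shows that going from the group of 10 heavy atoms to the one of 9, with the hydrogen-bond donor and acceptor counts unchanged, leaves the read-out within the scatter. No measurement available for this pair points to an explanation of the result.

Open, on these data alone, is whether the level in this assay would hold with a carboxylic acid in place of the hydroxycarbamoyl end, or with a chain longer than that of compound 1. Also open, as far as these compounds go, is how a primary amine on the saturated chain in place of the whole side group would read.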